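This account rests on a few compounds, and the source may have more. Where it says the series, first, only, none or still open, it means among the compounds named here.

Of the compounds shown here, two have so far been measured in a functional assay for inhibition of sodium-dependent dopamine transporter (Mus musculus); on this read-out higher numbers stand for an effect only at larger amounts of compound and lower numbers for an effect already at smaller amounts. Compound 1 `CN1Cc2c(NC(=O)CCl)cccc2C(c2ccccc2)C1` carries a chloromethyl group on the carbonyl carbon of its amide and gives 10 mg/kg in this assay. Compound 2 `CN1Cc2c(NC(=O)CCCl)cccc2C(c2ccccc2)C1` carries a 2-chloroethyl chain in that place and gives 19 mg/kg. The step of a 1.9-fold higher number from compound 1 to compound 2 (0.28 log units; within the scatter) lies within the scatter, so the two compounds cannot be told apart on this read-out. Compound 2 thus stands at the top of the two numbers shown, but with compound 1 within the scatter of it, so no order between them is claimed.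

Compound 3 `CN1Cc2c(NC(=O)OCCCl)cccc2C(c2ccccc2)C1` has not yet been measured. It differs from compound 2 in one place: 2-chloroethoxy in place of 2-chloroethyl on a carbonyl carbon. Within the data shown here, no measured step bears directly on this change. Among the measured compounds shown here, the only step available, a 1.9-fold higher number from compound 1 to compound 2 (0.28 log units; within the scatter), lengthened the chloroalkyl chain and stayed within the scatter. For the measured compounds named here, with no precedent for the added oxygen, the expected step for compound 3 in this assay is a small one, a 1.1-fold higher number from compound 2 to compound 3 (0.02 log units; within the scatter), within the scatter. Compound 3 is therefore estimated at 20 mg/kg, with a range from 8 mg/kg to 50 mg/kg.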

Compound 3, dose for half-maximal effect: 11 mg/kg
The estimate for compound 3 lay 1.8-fold (0.26 log units) above the measured number, within the range that was stated.
By their numbers in this assay, from the lowest: compounds 1, 3 and 2 (each within the scatter of the next).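

In this assay, the place on the carbonyl carbon whose other neighbour is the amide-type nitrogen now also accepts an oxygen within the chain: 2-chloroethoxy, which counts a hydrogen-bond acceptor where 2-chloroethyl counts none, gives a 1.7-fold lower number from compound 2 to compound 3 (0.24 log units; within the scatter) and stays within the scatter. Set against the shorter chloromethyl group, the same 2-chloroethoxy group gives a 1.1-fold higher number from compound 1 to compound 3 (0.04 log units; within the scatter), again within the scatter, so all three groups tried at this place remain indistinguishable on this read-out and the added oxygen shows no measurable effect here. Nothing available explains why the three numbers lie so close together.

As far as these compounds go, all three compounds carry a chlorine at the end of the chain, so it remains open whether the numbers would hold with a plain ethyl or ethoxy group, or with fluorine in place of the chlorine. From the compounds shown here alone, it is equally open whether a clearly larger step would appear at this place with a much longer chain, an amine or a carboxylic acid, any of which could show how much change this position tolerates.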